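Adding a Hydroxymethyl to a Weakly Cytotoxic Compound

This account rests on a few compounds, and the source may have more. Where it says the series, first, only, none or still open, it means among the compounds named here.

Measured compounds:
- compound 1, `OC1CNCc2nc(-c3ccc(N4CCCC4)cc3)sc21`, gives 25000 nM in a functional assay on HCT-116 cells (Homo sapiens) for cytotoxicity, read by sulforhodamine B assay, with a stated time of 2 days; a higher number here means a weaker inhibitor, a lower number a stronger inhibitor
- compound 2, `Cc1cc(N(C)C)ccc1-c1nc2c(s1)[C@H](O)CCC2`, gives > 100000 nM in this assay, which is a limit of the assay rather than a number

Among the compounds with values here, compound 1 holds the only finite value in this set. The value of compound 2 is a limit, so it sits at the limit of > 100000 nM in this assay, at which 1 of the 2 values shown sits, and no comparison with compound 1 can be drawn from it beyond that.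

Compound 3, `OCc1cc(N2CCCC2)ccc1-c1nc2c(s1)C(O)CNC2`, is not yet measured. It differs from compound 1 by hydroxymethyl in place of hydrogen on an aromatic carbon. Within the data shown here, no measured pair shows what such a change does here, so the expectation rests on compound 1 alone. Compound 3 is expected to stay close to compound 1, with a step of a 1.6-fold higher number from compound 1 to compound 3 (0.20 log units; within the scatter) in this assay that need not exceed the scatter. Compound 3 is therefore estimated at 40000 nM, within 10000 nM to 150000 nM.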

Compound 3, half-maximal inhibitory concentration: > 100000 nM
Compound 3: no number, only a limit; the forecaster's own chance of this, stated with the estimate: 30%; middle value at least 2.5-fold (0.39 log units) from the limit.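

In this assay, within the data shown here, hydroxymethyl in place of hydrogen on this aromatic carbon, ortho to a large group and meta to the pyrrolidin-1-yl group, gives an at least 4.0-fold higher number from compound 1 to compound 3 (0.60 log units; beyond the scatter) and is the first single change in this set that can be read, and it weakens compound 1 beyond the scatter. Compound 3 gives > 100000 nM, which is a limit of the assay and not a number, so only the lower bound of the step is known. Compound 3 therefore joins the compounds at the top of the range: the limit of > 100000 nM in this assay, at which 2 of the 3 values shown sit.

On these data alone, it remains open whether methyl, methoxy or a carboxylic acid on this aromatic carbon would preserve the number of compound 1, 25000 nM, or weaken it as well. Also open, as far as these compounds go, is whether hydroxymethyl on another carbon of this ring would have the same effect.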